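Swapping Acetyl for Pyrimidinyl on a Sulfonamide Nitrogen

This account rests on a few compounds, and the source may have more. Where it says the series, first, only, none or still open, it means among the compounds named here.

Compound 1 `CC(=O)NS(=O)(=O)c1ccc(N/C(S)=N\c2ccnc3cc(C(F)(F)F)ccc23)cc1`: 37600 nM
Compound 2 `N=C(N)NS(=O)(=O)c1ccc(N/C(S)=N\c2ccnc3cc(C(F)(F)F)ccc23)cc1`: 23900 nM
Compound 3 `O=S(=O)(Nc1nccs1)c1ccc(N/C(S)=N\c2ccnc3cc(C(F)(F)F)ccc23)cc1`: 27200 nM

These three compounds share one core and differ only in the group attached to a sulfonamide nitrogen. All were measured in a functional assay on AS49-RAW cells (Homo sapiens) for antiproliferative activity, read by sulforhodamine B assay, with a stated time of 48 h; on this read-out higher numbers stand for weaker inhibition and lower numbers for stronger inhibition. Compound 1 has the highest of the three numbers, but the gaps to the other two are small: a 1.4-fold lower number from compound 1 to compound 3 (0.14 log units; within the scatter) and a 1.6-fold lower number from compound 1 to compound 2 (0.20 log units; within the scatter), so the three compounds cannot be told apart on this read-out.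

Compound 4 `O=S(=O)(Nc1ncccn1)c1ccc(N/C(S)=N\c2ccnc3cc(C(F)(F)F)ccc23)cc1` has not yet been measured. It differs from compound 1 by pyrimidin-2-yl in place of acetyl on a sulfonamide nitrogen. Going by the values given here, the closest precedent is the step from compound 1 to compound 3, where a five-membered aromatic ring also replaced the acetyl group and the number moved only within the scatter; the step from compound 1 to compound 2 likewise stayed within the scatter. On that basis no change beyond the scatter is expected, a 1.3-fold lower number from compound 1 to compound 4 (0.10 log units; within the scatter). Compound 4 is therefore estimated at 30000 nM, with a plausible range from 13000 nM to 70000 nM.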

Compound 4, half-maximal inhibitory concentration: 37800 nM
For compound 4 the middle estimate is 1.3-fold (0.10 log units) below the measured one; measured number inside the range.
By their numbers in this assay, from the lowest: compounds 2, 3, 1 and 4 (each within the scatter of the next).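

In this assay, pyrimidin-2-yl on the sulfonamide nitrogen gives no number that can be told apart from the one given by acetyl (a 1.0-fold higher number from compound 1 to compound 4 (0.00 log units; within the scatter)), and the same holds against 1,3-thiazol-2-yl (a 1.4-fold higher number from compound 3 to compound 4 (0.14 log units; within the scatter)) and the open-chain group of compound 2 (a 1.6-fold higher number from compound 2 to compound 4 (0.20 log units; within the scatter)). So a six-membered aromatic ring with 2 hetero atoms can now be added to the groups at this position that stay within the scatter of one another, and none of the four separates from the rest. No measurement shown offers a reason for this flat picture.

From the compounds shown here alone, whether any group here can move the number beyond the scatter remains open, for example a plain hydrogen, a carboxylic acid or a longer chain ending in an amine. Whether changes elsewhere on the shared core would matter more also remains unanswered.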